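The source may hold more compounds than are shown below. What is called first, only, known or untested is meant among the compounds shown, and "the series" means these compounds.

In an ADME assay on BaF3 cells (Mus musculus) for cytotoxicity (a higher number here means that more compound is needed for the effect, a lower number that less compound is needed), compound 1 `NS(=O)(=O)c1cccc(-c2cc(Nc3ccc(OC(F)(F)F)cc3)ncn2)c1` gives > 10000 nM, which is a limit of the assay and not a number. Compound 2 `FC(F)(F)Oc1ccc(Nc2ncnc3c2cnn3CC2CCOC2)cc1` gives > 10000 nM in this assay, again a limit. Among the measured compounds shown here, the only orientation is therefore (the limit of > 10000 nM in this assay, at which 2 of the 2 values shown sit), so no step between measured compounds can be sized. Compound 3 `CS(=O)(=O)c1cccc(-c2cc(Nc3ccc(OC(F)(F)F)cc3)ncn2)c1` differs from compound 1 by methyl in place of amino on a sulfonyl sulfur, a change of one heavy atom with no ring involved. The step that the limit leaves unreadable from compound 1 to compound 3 is expected to be none beyond the scatter, with compound 3 most likely again reported only as a limit. Compound 3 is estimated at 15000 nM in this assay, within 5000 nM to 40000 nM.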

Compound 3, half-maximal effective concentration: > 10000 nM
Compound 3: no number, only a limit; the forecaster's own chance of this, stated with the estimate: 80%; the middle value does not contradict the limit.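

In this assay, among the compounds shown here, compound 1 and compound 3 both stand only as limits, so no step between them can be read. The compounds shown leave open what size, if any, the change from sulfamoyl to methylsulfonyl has.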